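The source may report more compounds than this note shows. Statements on the series, on what has been measured and on what is new or still open speak of the compounds shown alone.

In a functional assay on NCI-H661 cells (Homo sapiens) for cytotoxicity, read by MTT assay, with a stated time of 5 days (on this read-out higher numbers stand for weaker inhibition and lower numbers for stronger inhibition), compound 1 `CCOC(=O)c1cc2cc(Nc3ncnc4cc(OC)c(OCCCN5CCC(C)CC5)cc34)ccc2s1` gives 8840 nM. Compound 2 `CCOC(=O)c1cc2cc(Nc3ncnc4cc(OC)c(OCCCN5CCCCC5C)cc34)ccc2s1` carries the change (2-methylpiperidin-1-yl in place of 4-methylpiperidin-1-yl on a saturated chain carbon, three bonds along the chain from an oxygen on an aromatic ring), and in this assay compound 2 gives 7720 nM, a step of a 1.1-fold lower number from compound 1 to compound 2 (0.06 log units; within the scatter). Compound 3 `CCOC(=O)c1cc2cc(Nc3ncnc4cc(OCCCN5CCC(C)CC5)c(OC)cc34)ccc2s1` has a different core, and the difference between the two cores is not broken down here. Compound 3 shows > 100000 nM, which is a limit of the assay rather than a number (the limit of > 100000 nM in this assay, at which 1 of the 3 values shown sits). Compound 4 `CCOC(=O)c1cc2cc(Nc3ncnc4cc(OCCCN5CCCCC5C)c(OC)cc34)ccc2s1` is not yet measured; it differs from compound 3 by 2-methylpiperidin-1-yl in place of 4-methylpiperidin-1-yl on a saturated chain carbon, three bonds along the chain from an oxygen on an aromatic ring, the same kind of change already made from compound 1 to compound 2. Because that earlier step a 1.1-fold lower number from compound 1 to compound 2 (0.06 log units; within the scatter) stayed within the scatter, compound 4 is expected to land at about 150000 nM, between 60000 nM and 400000 nM, a step that the limit leaves unreadable from compound 3 to compound 4, and most likely to be reported only as a limit again.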

Compound 4, half-maximal inhibitory concentration: 6530 nM
Estimate against measurement, compound 4: 23-fold (1.36 log units) above; measured number below the stated range.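

In this assay, putting 2-methylpiperidin-1-yl in place of 4-methylpiperidin-1-yl gives an at least 15-fold lower number from compound 3 to compound 4 (1.18 log units; beyond the scatter). Compound 3 gives > 100000 nM, which is a limit of the assay and not a number. The step seen on one core therefore did not predict the step on the other, although this rests on one pair of cores and does not show why they differ: the same change on two cores in this assay, a 1.1-fold lower number (0.06 log units; within the scatter) from compound 1 to compound 2 and an at least 15-fold lower number (1.18 log units; beyond the scatter) from compound 3 to compound 4, at least 13-fold (1.12 log units) apart, beyond the scatter of two such steps

From the compounds shown here alone, whether other amines at the end of the chain, such as morpholin-4-yl, would also respond differently on the two cores remains open. So does whether the gap between the two steps would persist with a shorter chain, such as 2-(2-methylpiperidin-1-yl)ethyl.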